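Five-membered heteroaryl swap at the shared core

The compounds below may be only part of what the source reports. "The series", "measured", "known", "first", "only" and "open" are said of these compounds alone.

Within the data shown here, compound 2 `FC(F)(F)c1ccccc1OC1CCN(c2ncc(-c3ncco3)s2)CC1` gives 14 nM in an assay on microsomes from liver (strain Wistar) for inhibition of acyl-CoA desaturase 1 (Rattus norvegicus), read by HPLC, with stated times of 1 h and 60 min (a higher number here means a weaker inhibitor, a lower number a stronger inhibitor), the highest of the two numbers so far; the nearest is compound 1 `NC(=O)c1cnc(N2CCC(Oc3ccccc3C(F)(F)F)CC2)s1` at 3 nM. Among the measured compounds shown here, the only measured step at this position, a 4.7-fold higher number from compound 1 to compound 2 (0.67 log units; beyond the scatter), shows that a five-membered heteroaryl in place of carbamoyl costs a modest amount. Compound 3 `FC(F)(F)c1ccccc1OC1CCN(c2ncc(-c3ncon3)s2)CC1` carries 1,2,4-oxadiazol-3-yl in place of 1,3-oxazol-2-yl on an aromatic carbon. For the measured compounds named here, no measured step compares two such rings with each other, so only a small step is expected, a 1.4-fold higher number from compound 2 to compound 3 (0.15 log units; within the scatter), possibly none beyond the scatter. Compound 3 is therefore estimated at 20 nM, with a range from 7 nM to 60 nM.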

Compound 3, half-maximal inhibitory concentration: 4 nM
For compound 3 the middle estimate is 5.0-fold (0.70 log units) above the measured one; measured number below the stated range.
By their numbers in this assay, from the lowest: compounds 1 and 3 (each within the scatter of the next); then compound 2.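

In this assay the ring swap gives a 3.5-fold lower number from compound 2 to compound 3 (0.54 log units; beyond the scatter) and so shows that the choice of five-membered ring at this position matters, not only its presence. Carbamoyl to 1,2,4-oxadiazol-3-yl gives a 1.3-fold higher number from compound 1 to compound 3 (0.12 log units; within the scatter) and so shows that a heteroaryl here need not cost anything beyond the scatter, unlike 1,3-oxazol-2-yl. Nothing available accounts for the gap between the two rings.

From the compounds shown here alone, whether a nitrile, a carboxylic acid or an N-methyl amide on this carbon would match compound 3 stays open.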